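Chloro in Place of Amino at the Shared Core

The source may hold more compounds than are shown below. What is called first, only, known or untested is meant among the compounds shown, and "the series" means these compounds.

compound 1 `CCOC(=O)Nc1ncc(-c2ccccc2)c(C(C)(C)C)n1` — 24%
compound 2 `CC(C)(C)c1ccnc(N)n1` — 32%
compound 3 `CC(C)(C)c1ccnc(Nc2ccccc2)n1` — 21%

Of the compounds shown here, three have been measured in a functional assay on the whole organism for inhibition, with Rattus norvegicus as the target, with stated times of 1 h and 3.5 h, at a dose of 100 mg/kg by the oral route; on this read-out higher numbers stand for more inhibition at the one dose given (going by the name of the read-out) and lower numbers for less inhibition. On the numbers as they stand, compound 2 gives 32%, the highest of the three. The nearest number belongs to compound 1, which gives 24%, a figure within the usual scatter of that of compound 2, so the two cannot be placed in any order. The furthest belongs to compound 3, which gives 21%, a figure beyond the scatter below compound 2.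

Among the measured compounds shown here, no two of the measured compounds differ in a single place, so no measured step is available to set the size of a change at the shared core.

Compound 4 `CC(C)(C)c1ccnc(Cl)n1` has not yet been measured in this assay. It differs from compound 2 in one place: chloro in place of amino on an aromatic carbon.

For the measured compounds named here, with no measured step to lean on, the account rests on the value of compound 2 alone. The step from compound 2 to compound 4 is expected to be modest, a number 10 percentage points lower from compound 2 to compound 4 (within the scatter), in the direction of less inhibition and likely close to the scatter. Compound 4 is therefore estimated to give 22% in this assay, expected to fall between 5% and 40%.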

Compound 4, a percentage reported as inhibition, in the whole organism at one dose (the size of the read-out at that dose, not a potency): < 5%
Compound 4 gave a limit, no number; the forecaster's own chance of this, stated with the estimate: 5%; middle value at least 17 percentage points away from the limit.
By their numbers in this assay, from the lowest: compounds 3, 1 and 2 (each within the scatter of the next, the first and the last beyond it). At a limit, below all of these: compound 4.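

Swapping amino for chloro on the aromatic carbon between two ring nitrogen atoms gives the first single-place step at the shared core in this assay, and it reads a number at least 27 percentage points lower from compound 2 to compound 4 (beyond the scatter). The earlier compounds shown here could not show that this position is sensitive to such a swap, but this step shows that a change of one heavy atom there is enough to move the read-out beyond the scatter. The result for compound 4 marks a limit of the assay and not a number, so the true size of the step stays unknown: the limit of < 5% in this assay, at which 1 of the 4 values shown sits.

Among the compounds shown here, the single step cannot separate the effect of losing amino, with its counted hydrogen-bond donor and acceptor, from the effect of bringing in chloro, and a methoxy, methyl or hydroxyl group at this position would be needed to tell the two apart. The compounds shown also leave open whether the same swap would produce a step of similar size on the core of compound 1, which carries a phenyl group in addition to the tert-butyl group.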